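The source may hold more compounds than are shown below. What is called first, only, known or untested is meant among the compounds shown, and "the series" means these compounds.

In a functional assay on MDA-MB-468 cells (Homo sapiens) for antiproliferative activity, read by WST assay, with a stated time of 3 days (on this read-out lower numbers stand for stronger inhibition and higher numbers for weaker inhibition), compound 1 (`O=c1cc(I)n([C@@H]2O[C@H](CO)[C@@H](O)[C@H]2O)c(=O)[nH]1`) reads > 50000 nM and this is a limit. Compound 2 (`O=c1[nH]c(=O)n([C@@H]2O[C@H](CO)[C@@H](O)[C@H]2O)c(I)c1F`) reads > 50000 nM and this too is only a limit. Compound 3 (`CCc1c(F)c(=O)[nH]c(=O)n1[C@@H]1O[C@H](CO)[C@@H](O)[C@H]1O`) gives a true number at 5300 nM in the same read-out.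

Compound 4 (`O=c1[nH]c(=O)n([C@@H]2O[C@H](CO)[C@@H](O)[C@H]2O)c(I)c1Br`) alters compound 2 in one place: bromo in place of fluoro on an aromatic carbon with bromo in place of fluoro on an aromatic carbon, ortho to an iodo group. Among the compounds with values here, two measured steps bear on this. The only one touching that aromatic carbon is a step that the two limits leave unreadable from compound 1 to compound 2 and it gives no usable size. The other is an at least 9.4-fold lower number from compound 2 to compound 3 (0.97 log units; beyond the scatter) but it replaces the iodo group, which compound 4 keeps, so it offers little guidance.

The expected outcome is a number no higher from compound 2 to compound 4 (the limit leaves the size open) with no gain beyond the scatter anticipated in this assay and a report at the limit likely. Compound 4 is estimated at 50000 nM with an expected range of 15000 nM to 100000 nM in this read-out.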

Compound 4, half-maximal inhibitory concentration: > 50000 nM
Compound 4 was reported as a limit; the forecaster's own chance of this, stated with the estimate: 70%; the middle value lies on the limit itself.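

No step can be read among compound 1, compound 2 and compound 4, because all three are reported only as the same limit: the limit of > 50000 nM in this assay, at which 3 of the 4 values shown sit.

The compounds shown leave open how hydrogen, fluoro and bromo on that aromatic carbon compare.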